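Adding a Second Chloro to the Shared Core

The source may hold more compounds than are shown below. What is called first, only, known or untested is meant among the compounds shown, and "the series" means these compounds.

Compound 1 `ClCc1ccc(Cn2cnc3c(Cl)ncnc32)cc1`: 3010 nM
Compound 2 `ClCc1ccccc1Cn1cnc2c(Cl)nc(Cl)nc21`: 1020 nM
Compound 3 `ClCc1cccc(Cn2cnc3c(Cl)ncnc32)c1`: 3460 nM

In a functional assay on U-251 cells (Homo sapiens) for cytotoxicity, read by sulforhodamine B assay, with a stated time of 48 h (on this read-out lower numbers stand for stronger inhibition of growth and higher numbers for weaker inhibition of growth), compound 3 gives the highest number of the three. Compound 1 lies within the scatter of it, so the two cannot be ranked, while compound 2 stands beyond the scatter at a lower number. Compound 4 `ClCc1cccc(Cn2cnc3c(Cl)nc(Cl)nc32)c1` differs from compound 3 by chloro in place of hydrogen on an aromatic carbon, a chloro in place of hydrogen on an aromatic carbon between two ring nitrogen atoms. Among the measured compounds shown here, no measured pair shows this change on its own; compound 2 carries the same second chloro but also a different arrangement of the benzyl piece. A modest step downward is expected, a 2.3-fold lower number from compound 3 to compound 4 (0.36 log units; beyond the scatter). Compound 4 is therefore estimated at 1500 nM, with a range from 600 nM to 4000 nM.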

Compound 4, concentration for total growth inhibition: 3090 nM
Compound 4: middle estimate off by 2.1-fold (0.31 log units), on the low side, and the stated range covers the measured number.
By their numbers in this assay, from the lowest: compound 2; then compounds 1, 4 and 3 (each within the scatter of the next).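

In this assay, among the compounds shown here, this pair isolates the change for the first time: chloro in place of hydrogen on an aromatic carbon between two ring nitrogen atoms gives a 1.1-fold lower number from compound 3 to compound 4 (0.05 log units; within the scatter) and so has no readable effect here. At this position, with the benzyl piece of compound 3, the second chloro can be added without a measurable difference. Nothing available explains this result.

Going by these compounds, whether an amine or a methoxy group at this position would shift the number remains open. So does whether the same chloro change behaves alike with the benzyl piece of compound 2.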